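The compounds below may be only part of what the source reports. "The series", "measured", "known", "first", "only" and "open" are said of these compounds alone.

Within the data shown here, in a functional assay on HL-60 cells (Homo sapiens) for inhibition, read by MTT assay, with a stated time of 48 h, tested at 10 uM (on this read-out higher numbers stand for more inhibition of growth at the one concentration tested and lower numbers for less inhibition of growth), three compounds with one shared core have numbers so far: compound 1 (`CN1CC[C@H](c2c(O)cc(O)c3c(=O)cc(/C=C/c4ccccc4)oc23)[C@H](O)C1`) gives 91% while compound 2 (`CN1CC[C@H](c2c(O)cc(O)c3c(=O)cc(/C=C/c4ccc(Cl)cc4)oc23)[C@H](O)C1`) gives 58% and compound 3 (`CN1CC[C@H](c2c(O)cc(O)c3c(=O)cc(/C=C/c4c(F)c(F)c(F)c(F)c4F)oc23)[C@H](O)C1`) gives 80% on the same scale. Compound 3 therefore stands second highest of the three, under compound 1 and over compound 2.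

The next compound is compound 4 (`CN1CC[C@H](c2c(O)cc(O)c3c(=O)cc(/C=C/c4cccc(F)c4)oc23)[C@H](O)C1`), which has 3-fluorophenyl in place of 2,3,4,5,6-pentafluorophenyl on a double-bonded chain carbon bound to a double-bonded chain carbon. The counted change is 3-fluorophenyl in place of 2,3,4,5,6-pentafluorophenyl on a double-bonded chain carbon bound to a double-bonded chain carbon and the rest of the structure stays the same.

Among the measured compounds shown here, three measured steps bear on this. The closest is a number 11 percentage points lower from compound 1 to compound 3 (beyond the scatter) on exchanging phenyl for 2,3,4,5,6-pentafluorophenyl. A caution comes from a number 33 percentage points lower from compound 1 to compound 2 (beyond the scatter) on adding one chloro, and the reverse gap appears in a number 22 percentage points higher from compound 2 to compound 3 (beyond the scatter) between the two halogenated compounds. For the measured compounds named here, no measured compound carries a single fluorine, so the direction is uncertain and the range must stay wide, reaching further down than up.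

The step expected is a number 4 percentage points lower from compound 3 to compound 4 (within the scatter) and that means none beyond the scatter. Compound 4 is estimated at 76% with an expected range from 56% to 92% on this read-out.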

Compound 4, percent growth inhibition at one concentration: 60%
Beside the measured number, compound 4's estimate is 16 percentage points above it, within the range that was stated.
By their numbers in this assay, from the lowest: compounds 2 and 4 (each within the scatter of the next); then compound 3; then compound 1.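

In this assay, the 3-fluorophenyl group shows that one fluorine at this place is enough for a large loss: fluoro in place of hydrogen gives a number 31 percentage points lower from compound 1 to compound 4 (beyond the scatter), the same size class as chloro in place of hydrogen, with a number 33 percentage points lower from compound 1 to compound 2 (beyond the scatter). The number of halogen atoms on the ring does not order the results, and compound 3 goes against any such trend: going from 2,3,4,5,6-pentafluorophenyl to 3-fluorophenyl on a double-bonded chain carbon bound to a double-bonded chain carbon gives a number 20 percentage points lower from compound 3 to compound 4 (beyond the scatter), whereas 3-fluorophenyl in place of 4-chlorophenyl gives only a number 2 percentage points higher from compound 2 to compound 4 (within the scatter), so the two rings with a single halogen cannot be told apart on this read-out. No measurement at hand offers an explanation for these steps.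

From the compounds shown here alone, compound 2 and compound 4 differ in both the halogen and its ring place, so what a 4-fluorophenyl or a 3-chlorophenyl group would give here remains open, and with it which of the two changes matters. Also open, going by these compounds, is how a ring carrying a methoxy group or a dimethylamino group, rather than a halogen, would read at this place.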